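The source may hold more compounds than are shown below. What is called first, only, known or untested is meant among the compounds shown, and "the series" means these compounds.

Measured so far:
compound 1, `COc1cc(C(C)=O)ccc1OCCCN1CCC(C(c2ccccc2)c2ccccc2)CC1`, gives 6.31 nM
compound 2, `COc1cc(C(C)O)ccc1OCCCN1CCC(C(c2ccc(F)cc2)c2ccc(F)cc2)CC1`, gives 10 nM

Both numbers come from a functional assay (aorta) with Oryctolagus cuniculus as the target; on this read-out lower numbers stand for tighter binding and higher numbers for weaker binding. Compound 2 has the higher of the two numbers, yet its gap to compound 1 lies within the usual scatter, so the two cannot be told apart on these data. Compound 3, `Fc1ccc(C(c2ccc(F)cc2)C2CCN(CCCOc3ccc(Cl)cc3)CC2)cc1`, is not yet measured. It differs from compound 2 by 4-chlorophenyl in place of 4-(1-hydroxyethyl)-2-methoxyphenyl on an oxygen on a saturated carbon. Going by the values given here, no measured pair shows this change, so nothing is known of its size in this assay. The step is estimated as a 2.5-fold higher number from compound 2 to compound 3 (0.40 log units; beyond the scatter), a modest weakening. Compound 3 is therefore expected to give about 25 nM, somewhere between 6 nM and 100 nM.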

Compound 3, dissociation constant: 2 nM
Estimate against measurement, compound 3: 13-fold (1.10 log units) above, and the stated range ends above it.
By their numbers in this assay, from the lowest: compound 3; then compounds 1 and 2 (each within the scatter of the next).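

In this assay, placing 4-chlorophenyl instead of 4-(1-hydroxyethyl)-2-methoxyphenyl on the oxygen gives a 5.0-fold lower number from compound 2 to compound 3 (0.70 log units; beyond the scatter). The position therefore accepts a smaller aromatic group with no hydrogen-bond donors or acceptors, and tighter binding is retained without the hydroxyl and methoxy groups. Nothing available explains the gain.

The change alters several features at once, so the contributions of adding the chlorine and removing the two oxygen-bearing groups remain inseparable. As far as these compounds go, whether 4-bromophenyl or 4-cyanophenyl on the same oxygen would match 4-chlorophenyl also remains open.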